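Thiazole for pyrimidine on the amine-linked arm: solubility note

A few compounds are considered here, and "the series" means these few. Any claim that something is new, unique, unknown or untested is made for them only; others in the source may bear on it.

For the measured compounds named here, compound 1 `Cc1cc(NCc2ncccn2)n2nc(C)c(-c3ccccc3)c2n1` holds the only number in a physicochemical assay for solubility, read by HPLC, using the shake flask method, measured as kinetic solubility, with a stated time of 2 h, at pH 7.4 (a lower number here means a less soluble compound, a higher number a more soluble compound), where compound 1 gives 37900 nM. Compound 2 `Cc1cc(NCc2ccco2)n2nc(C)c(-c3ccccc3)c2n1` gives only a limit in this assay, < 5000 nM. Going by the values given here, the one measured step, an at least 7.5-fold lower number from compound 1 to compound 2 (0.87 log units; beyond the scatter), therefore reads as a floor: the limit of < 5000 nM in this assay, at which 1 of the 2 values shown sits. Compound 3 `Cc1cc(NCc2nccs2)n2nc(C)c(-c3ccccc3)c2n1` awaits measurement; its change from compound 1 is 1,3-thiazol-2-yl in place of pyrimidin-2-yl on a saturated chain carbon bound to a nitrogen on an aromatic ring. The measured step sits at the same place and again brings in a five-membered aromatic ring with 2 hetero atoms, so a clear drop in this assay is expected, possibly ending at the limit once more. For compound 3 the expected step is a 4.7-fold lower number from compound 1 to compound 3 (0.68 log units; beyond the scatter). Compound 3 is estimated at 8000 nM, with a range of 3000 nM to 25000 nM.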

Compound 3, solubility: 108000 nM
Compound 3: the middle estimate sits 14-fold (1.13 log units) below what was measured; the whole stated range lies below it.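

A five-membered aromatic ring with 2 hetero atoms at this place does not by itself lower the number in this assay: 1,3-thiazol-2-yl in place of pyrimidin-2-yl raises it (a 2.8-fold higher number from compound 1 to compound 3 (0.45 log units; beyond the scatter)). The two five-membered rings also lie far apart (an at least 21-fold higher number from compound 2 to compound 3 (1.33 log units; beyond the scatter)), so ring size alone does not set the read-out across these compounds. That step is only a floor, since compound 2 gives a limit and not a number: the limit of < 5000 nM in this assay, at which 1 of the 3 values shown sits.

On these data alone, how phenyl or pyridin-2-yl at this place would compare remains open. So does whether the thiazole gain persists with a longer chain in place of the methyl link.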